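The source may report more compounds than this note shows. Statements on the series, on what has been measured and on what is new or still open speak of the compounds shown alone.

Of the compounds shown here, two built on the shared core have so far been tested in a toxicity assay on THP-1 cells (Homo sapiens) for inhibition; on this read-out higher numbers stand for lower toxicity in this test and lower numbers for higher toxicity in this test. Compound 1 `COc1cccc(-c2cnc(NC(=O)c3ccc(F)cc3)n2C)c1` is one of them. In this test compound 1 gives > 100000 nM, which is a limit of the assay rather than a measured number. Compound 2 `COc1ccc(-c2cnc(NC(=O)c3ccccc3Br)n2C)cc1` is the other. In this assay compound 2 gives > 100000 nM, again a limit of the assay and not a number. Compound 2 therefore stands where every value obtained so far stands, namely at the limit of > 100000 nM in this assay, at which 2 of the 2 values shown sit, so nothing in the data separates compound 2 from compound 1 on this read-out.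

Compound 3 `COc1ccc(-c2cnc(NC(=O)c3ccccc3Cl)n2C)cc1` has not yet been measured in this assay. It is related to compound 2 by a single change, (chloro in place of bromo on an aromatic carbon), and this is the step the account follows. Going by the values given here, with both measured compounds sitting at a limit, there is no measured step from which to scale an expectation, and the change from bromo to chloro is small. Compound 3 is therefore expected to show a step of a number no higher from compound 2 to compound 3 (the limit leaves the size open), that is, none beyond the scatter. The estimate for compound 3 in this assay is 100000 nM, expected to fall between 40000 nM and 400000 nM.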

Compound 3, half-maximal cytotoxic concentration: > 50000 nM
Compound 3 was reported as a limit (the forecaster's own chance of this, stated with the estimate: 80%); the middle value is on the limit's open side.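

In this assay compound 3 gives > 50000 nM, a limit of the assay and not a number. With compound 2 also at a limit, no step can be read from compound 2 to compound 3. The compounds shown leave open what number any of them would give on this read-out, and whether chloro in place of bromo changes it.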